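This account rests on a few compounds, and the source may have more. Where it says the series, first, only, none or still open, it means among the compounds named here.

Of the compounds shown here, two of one series have been measured. Compound 1 `COc1ccc(-c2cc(/C=C/C(=O)c3ccc(N)cc3)[nH]n2)cc1` and compound 2 `COc1cc(-c2cc(/C=C/C(=O)c3ccc(N)cc3)[nH]n2)cc(OC)c1OC` share a core and differ in the methoxy pattern on one aromatic ring. In a functional assay on MCF7 cells (Homo sapiens) for cytotoxicity, read by sulforhodamine B assay, with a stated time of 48 h, tested at 100 uM (a lower number here means a stronger effect, a higher number a weaker effect of the compound at the concentration tested), compound 1 gives -68%. In this assay compound 2 gives -57%, the higher of the two numbers, and the gap to compound 1 falls beyond the usual scatter, so compound 2 shows the weaker effect of the pair on the numbers shown.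

Compound 3 `COc1ccc(C(=O)/C=C/c2cc(-c3cc(OC)c(OC)c(OC)c3)n[nH]2)cc1` has not been measured. It differs from compound 2 by methoxy in place of amino on an aromatic carbon, with the change on the aromatic ring that carries the carbonyl, the 4-aminophenyl of compound 2 becoming 4-methoxyphenyl. Going by the values given here, no measured pair shows this change, so its size cannot be read from the data.

For compound 3 a modest step toward a weaker effect is expected, of the size a number 12 percentage points higher from compound 2 to compound 3 (beyond the scatter), which lies near the edge of the scatter rather than clearly beyond it. The value expected for compound 3 in this assay is -45%, within a range from -75% to -10%.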

Compound 3, a percentage reported as activity, at one concentration (the size of the read-out at that concentration, not a potency): -69%
Compound 3: middle estimate off by 24 percentage points, on the high side; measured number inside the range.
By their numbers in this assay, from the lowest: compounds 3 and 1 (each within the scatter of the next); then compound 2.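

Until now every measured compound carried the 4-aminophenyl, so nothing showed whether this position could tolerate a change. In this assay the move from 4-aminophenyl to 4-methoxyphenyl, on the ring that carries the carbonyl, gives a number 12 percentage points lower from compound 2 to compound 3 (beyond the scatter) and so a stronger effect at the concentration tested, showing that in this pair the amino group, para to a large group, is not needed for the effect and that methoxy serves better there. Nothing in the data shown explains why this exchange moves the number.

As far as these compounds go, with one pair carrying this change, it remains open whether the same step would appear with the methoxy pattern of compound 1 on the other aromatic ring, and the single concentration gives the size of the read-out rather than a potency. Also open, from the compounds shown here alone, is how a hydroxy group, a dimethylamino group, a fluorine atom or a longer alkoxy chain such as ethoxy would read at this position.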